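This account rests on a few compounds, and the source may have more. Where it says the series, first, only, none or still open, it means among the compounds named here.

Measured compounds:
compound 1, `O=C(Nc1cccc(-n2cc(-c3ccncc3)c(-c3ccc(Cl)c(O)c3)n2)c1)Nc1ccc(Cl)c(Cl)c1`, 9680 nM
compound 2, `COc1cc(-c2nn(-c3cccc(NC(=O)Nc4ccc(Cl)c(C(F)(F)F)c4)c3)cc2-c2ccncc2)ccc1Cl`, 4180 nM

Of the compounds shown here, two have been measured in a functional assay on U-251 cells (Homo sapiens) for inhibition, read by sulforhodamine B assay, with a stated time of 48 h; a higher number here means a weaker inhibitor of growth, a lower number a stronger inhibitor of growth. Compound 1 gives 9680 nM. Compound 2 gives 4180 nM, the lower of the two numbers, with compound 1 standing beyond the scatter above it. The two differ in two places at once, so no single step can be read from them.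

Compound 3, `O=C(Nc1cccc(-n2cc(-c3ccncc3)c(-c3ccc(Cl)c(O)c3)n2)c1)Nc1ccc(Cl)c(C(F)(F)F)c1`, has not yet been measured. It departs from compound 2 by hydrogen in place of methyl on an oxygen on an aromatic ring. Within the data shown here, since no pair measured here isolates this change, the size of its effect is unknown; a modest step is expected, if any, more likely toward a somewhat higher number than a lower one, and it may well stay within the scatter. Compound 3 is therefore estimated at 5500 nM, with a plausible range from 2500 nM to 12000 nM. The step that this estimate means, a 1.3-fold higher number from compound 2 to compound 3 (0.12 log units; within the scatter), is expected to be small.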

Compound 3, concentration for total growth inhibition: 1230 nM
Compound 3: middle estimate off by 4.5-fold (0.65 log units), on the high side; the whole stated range lies above it.
By their numbers in this assay, from the lowest: compound 3; then compound 2; then compound 1.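

In this assay, the change from methoxy to hydroxy gives a 3.4-fold lower number from compound 2 to compound 3 (0.53 log units; beyond the scatter), showing that this place on the 4-chloro-3-methoxyphenyl group responds to the change, with hydroxy giving the stronger inhibitor of growth of this pair. With hydroxy held fixed, trifluoromethyl in place of chloro on an aromatic carbon gives a 7.9-fold lower number from compound 1 to compound 3 (0.90 log units; beyond the scatter), so this second place also matters and compound 3 is the strongest inhibitor of growth of the three. Nothing measured here bears on why either step occurs.

From the compounds shown here alone, whether the hydroxy step holds with chloro in place of trifluoromethyl stays open, as compound 1 and compound 2 differ in two places and cannot settle it. Also open, going by these compounds, is how an amine or a longer ethoxy chain would compare with hydroxy, and whether a nitrile could stand in for trifluoromethyl.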